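Removing the cyclohexylsulfanyl arm from compound 2

The source may hold more compounds than are shown below. What is called first, only, known or untested is meant among the compounds shown, and "the series" means these compounds.

Compound 2 `CC(C(=O)NCc1ccc(C(F)(F)F)cc1SC1CCCCC1)c1ccc(NS(C)(=O)=O)c(F)c1` gives 0.5 nM in an assay on CHO cells for antagonist activity at transient receptor potential cation channel subfamily V member 1 (Homo sapiens), read by FLIPR (a lower number here means a stronger inhibitor, a higher number a weaker inhibitor), the lowest of the two numbers measured; compound 1 `CC(C(=O)NCc1ccc(C(F)(F)F)cc1N1CCN(c2ccccc2)CC1)c1ccc(NS(C)(=O)=O)c(F)c1` gives 2 nM in this assay. Within the data shown here, the single measured step, a 4.0-fold lower number from compound 1 to compound 2 (0.60 log units; beyond the scatter), shows that the group on this aromatic carbon moves the number beyond the scatter, though it compares two groups of similar size. Compound 3 `CC(C(=O)NCc1ccc(C(F)(F)F)cc1F)c1ccc(NS(C)(=O)=O)c(F)c1` carries the change (fluoro in place of cyclohexylsulfanyl on an aromatic carbon), ortho to a large group and meta to a trifluoromethyl group. Among the measured compounds shown here, no measured pair shows what a small group at this place does, so the expectation rests on the one step and on the size of the group lost. A rise in the number beyond the scatter is expected, a 16-fold higher number from compound 2 to compound 3 (1.20 log units; beyond the scatter), the direction being a loss of potency. Compound 3 is therefore estimated at 8 nM, with a range from 1.5 nM to 50 nM.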

Compound 3, inhibition constant: 68.7 nM
Compound 3: the middle estimate sits 8.6-fold (0.93 log units) below what was measured; measured number above the stated range.
By their numbers in this assay, from the lowest: compound 2; then compound 1; then compound 3.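

The change from either large group to fluoro on this aromatic carbon costs far more in this assay than the exchange of one large group for the other: fluoro in place of cyclohexylsulfanyl gives a 140-fold higher number from compound 2 to compound 3 (2.14 log units; beyond the scatter) and fluoro in place of 4-phenylpiperazin-1-yl gives a 34-fold higher number from compound 1 to compound 3 (1.54 log units; beyond the scatter) in the same assay. Among these three compounds, the two with a large ring-bearing group therefore sit close together compared with compound 3, although the sulfur-linked and nitrogen-linked groups still differ beyond the scatter. Nothing shown explains the loss.

Open, as far as these compounds go, is whether the potency returns gradually or only with a full ring, which a methylsulfanyl or a butylsulfanyl chain at this place would test. Also open, from the compounds shown here alone, is whether the sulfur matters, which a cyclohexylamino or cyclohexyloxy group would separate from the cyclohexyl ring.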